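Swapping the aryl group on the acyl sulfonamide core

This account rests on a few compounds, and the source may have more. Where it says the series, first, only, none or still open, it means among the compounds named here.

Measured compounds:
- compound 1, `CCCCOC(=O)CC1c2cccc(C)c2S(=O)(=O)N1C(=O)/C=C/c1cc(F)cc(Cl)c1`: "not determined" (no result reported)
- compound 2, `CCCCOC(=O)CC1c2cccc(C)c2S(=O)(=O)N1C(=O)c1ccc(Cl)cc1`: 2140 nM

Two compounds share a core and differ only in the group attached to the carbonyl carbon. For compound 1 no number has been reported. For the measured compounds named here, in an assay on HEK-Blue hNOD1 cells for antagonist activity at Nucleotide-binding oligomerization domain-containing protein 1 (Homo sapiens), read by reporter gene assay, with stated times of 3 h and 20 h (on this read-out lower numbers stand for stronger inhibition and higher numbers for weaker inhibition), compound 2 gives 2140 nM and is thus the only compound here with a number, so there is no measured step of this kind to compare against.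

The next compound is compound 3, `CCCCOC(=O)CC1c2cccc(C)c2S(=O)(=O)N1C(=O)c1ccccc1C(F)(F)F`. It arises from compound 2 through the change (2-(trifluoromethyl)phenyl in place of 4-chlorophenyl on a carbonyl carbon). Going by the values given here, nothing among the measured compounds shows how such an exchange of the aromatic group on the carbonyl carbon shifts the readout, so the expectation must stay wide.

The step expected is a 1.4-fold higher number from compound 2 to compound 3 (0.15 log units; within the scatter), that is, little movement, or at most a modest weakening that could still fall within the usual scatter. For compound 3 the estimated value in this assay is 3000 nM, with a range from 1000 nM to 10000 nM.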

Compound 3, half-maximal inhibitory concentration: 1100 nM
Beside the measured number, compound 3's estimate is 2.7-fold (0.44 log units) above it; measured number inside the range.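

For the compounds shown here, this exchange gives the first measured step at this position: in this assay, the change is a 1.9-fold lower number from compound 2 to compound 3 (0.29 log units; within the scatter), which lies within the scatter, so the two compounds cannot be told apart on this read-out. The carbonyl carbon can therefore carry either 4-chlorophenyl or 2-(trifluoromethyl)phenyl without a difference that stands out from repeated measurements, even though the entering group has more heavy atoms and brings fluorine in place of chlorine. No supporting measurement is available to explain why these two aromatic groups read alike, and a single step within the scatter sets no trend for this position.

The compounds shown leave open how far this tolerance extends, for example whether an unsubstituted phenyl, a pyridine ring or a phenyl ring carrying a carboxylic acid or an amine would keep a similar reading. They also leave open whether a longer link between the carbonyl carbon and the aromatic ring changes the result, or whether replacing the aromatic ring with a saturated cyclohexyl group does.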